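This account rests on a few compounds, and the source may have more. Where it says the series, first, only, none or still open, it means among the compounds named here.

Compound 3 `CCCCC(Oc1ccc2c(=O)c(-c3ccc(O)cc3)coc2c1)C(=O)OCC` carries a butyl group where compound 2 `CCOC(=O)COc1ccc2c(=O)c(-c3ccc(O)cc3)coc2c1` carries a hydrogen. In an assay (Cricetulus griseus) for inhibition of aldehyde dehydrogenase, mitochondrial (Homo sapiens) (on this read-out lower numbers stand for stronger inhibition and higher numbers for weaker inhibition), compound 3 gives 4500 nM, the highest number among the three measured compounds; compound 2 gives 130 nM, and compound 1 `O=c1c(-c2ccc(O)cc2)coc2cc(OCCOCCOCCO)ccc12` gives 40 nM. The step of a 3.3-fold higher number from compound 1 to compound 2 (0.51 log units; beyond the scatter) is modest, whereas the step of a 35-fold higher number from compound 2 to compound 3 (1.54 log units; beyond the scatter) is large. Compound 4 `CCCCCCC(Oc1ccc2c(=O)c(-c3ccc(O)cc3)coc2c1)C(=O)OCC` differs from compound 3 by ethyl in place of hydrogen on a saturated chain carbon, five bonds along the chain from a carbonyl carbon and an oxygen on an aromatic ring, so the butyl chain of compound 3 becomes a hexyl chain in compound 4. Within the data shown here, the step that bears directly on this change is the one from compound 2 to compound 3, which altered the same saturated chain carbon and moved this assay toward a higher number by a large amount. The step from compound 1 to compound 2 concerns a different part of the molecule and bears on it only indirectly. Because a 35-fold higher number from compound 2 to compound 3 (1.54 log units; beyond the scatter) was large and toward weaker inhibition, a further lengthening of the chain is expected to move the number up again, though the added ethyl sits further along the chain and the step is expected to be smaller. The expected step is a 2.0-fold higher number from compound 3 to compound 4 (0.30 log units; within the scatter). Compound 4 is therefore estimated at 9000 nM, within a range from 3000 nM to 30000 nM.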

Compound 4, half-maximal inhibitory concentration: 7200 nM
Compound 4: middle estimate off by 1.3-fold (0.10 log units), on the high side; low and high end bracket the measured number.
By their numbers in this assay, from the lowest: compound 1; then compound 2; then compounds 3 and 4 (each within the scatter of the next).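

In this assay the added ethyl gives a 1.6-fold higher number from compound 3 to compound 4 (0.20 log units; within the scatter) and no more, so on this saturated chain carbon the butyl chain and the hexyl chain cannot be told apart. Set against the hydrogen, the hexyl chain gives a 55-fold higher number from compound 2 to compound 4 (1.74 log units; beyond the scatter) and remains a large step, as the butyl step was. Among these compounds, then, the large move on this carbon goes with putting a chain in place of hydrogen and not with taking butyl out to hexyl, a distinction that the earlier compounds, with only one chain on this carbon, could not draw.

The compounds shown leave open where between hydrogen and butyl the large move arises, which a methyl, ethyl or propyl on this carbon would show, and whether an octyl chain, a branched chain or a chain ending in an amine would read like butyl and hexyl, as well as whether a carboxylic acid in place of the ethyl ester would keep the same picture. Nothing given about these compounds accounts for the values or for the flat reading from butyl to hexyl.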